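This account rests on a few compounds, and the source may have more. Where it says the series, first, only, none or still open, it means among the compounds named here.

Compound 2 `Oc1ccc(Nc2ccc(N3CC4CC(C3)N4)cn2)cc1` carries a hydroxy group on the outer phenyl ring of the shared core. For the measured compounds named here, in an assay on HEK293 cells for displacement of a labelled ligand from Neuronal acetylcholine receptor; alpha3/beta4 (Homo sapiens) (on this read-out lower numbers stand for stronger inhibition and higher numbers for weaker inhibition), compound 2 gives 165 nM, the higher of the two numbers measured so far. Going by the values given here, its only measured neighbour is compound 1 `O=[N+]([O-])c1ccc(Nc2ccc(N3CC4CC(C3)N4)cn2)cc1`, which bears a nitro group in the same place and gives 25 nM in this assay. The step of a 6.6-fold higher number from compound 1 to compound 2 (0.82 log units; beyond the scatter) shows that the group at this position moves the number well beyond the ordinary scatter.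

Compound 3 `Fc1ccc(Nc2ccc(N3CC4CC(C3)N4)cn2)cc1` is the next variation at the same site: fluoro in place of hydroxy on an aromatic carbon. Among the compounds with values here, no measured pair covers a hydroxy-to-fluoro exchange, so the step from compound 1 to compound 2 is the only guide. It showed that the hydroxy compound gave the weaker number, and a third group at this position could plausibly land anywhere between the two measured values or near compound 2.

For compound 3 the expectation is a modest improvement, the step of a 2.8-fold lower number from compound 2 to compound 3 (0.44 log units; beyond the scatter), with an estimated value of 60 nM and a likely range from 20 nM to 180 nM.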

Compound 3, inhibition constant: 13 nM
Beside the measured number, compound 3's estimate is 4.6-fold (0.66 log units) above it, and the stated range ends above it.
By their numbers in this assay, from the lowest: compounds 3 and 1 (each within the scatter of the next); then compound 2.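

Replacing the hydroxy with fluoro gives a 13-fold lower number from compound 2 to compound 3 (1.10 log units; beyond the scatter) in this assay, so this position can move the number a long way even when one heavy atom is exchanged for another. The comparison with the nitro compound gives a 1.9-fold lower number from compound 1 to compound 3 (0.28 log units; within the scatter), which lies within the usual scatter, so fluoro and nitro cannot be told apart here, and compound 2 alone stands apart among these three, with a clearly higher number than either of the others. Hydroxy brings a hydrogen-bond donor and a hydrogen-bond acceptor, and fluoro is counted as having neither, but the data offer no measurement that explains the change in binding.

Three groups cannot show whether hydroxy is a rare poor choice at this position or one of many, and an amine, a methoxy group or a chlorine in the same place would help to settle that. From the compounds shown here alone, it also remains open whether fluoro keeps its number when the shared core is changed elsewhere, or how compound 3 behaves at any other receptor.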